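The source may hold more compounds than are shown below. What is called first, only, known or untested is meant among the compounds shown, and "the series" means these compounds.

Going by the values given here, compound 2 `O=C(Nc1ccc(-n2cc(-c3ccncc3)c(-c3ccc(Cl)c(O)c3)n2)cc1)c1cc(Cl)cc(Cl)c1` sits at the lower end of the two numbers measured so far in a functional assay on LOX IMVI cells (Homo sapiens) for antiproliferative activity, read by sulforhodamine B assay, with a stated time of 48 h; a lower number here means a stronger inhibitor, a higher number a weaker inhibitor: compound 2 gives 1190 nM. Among the compounds with values here, its only neighbour is compound 1 `O=C(Nc1ccc(-n2cc(-c3ccncc3)c(-c3ccc(Cl)c(O)c3)n2)cc1)Nc1ccc(Cl)c(C(F)(F)F)c1`, which in this assay gives 1440 nM; the one step known, a 1.2-fold lower number from compound 1 to compound 2 (0.08 log units; within the scatter), replaced (4-chloro-3-(trifluoromethyl)phenyl)amino on the carbonyl carbon with 3,5-dichlorophenyl. Compound 3 `O=C(Nc1ccc(-n2cc(-c3ccncc3)c(-c3ccc(Cl)c(O)c3)n2)cc1)c1ccc(Cl)c(C(F)(F)F)c1` takes the change (4-chloro-3-(trifluoromethyl)phenyl in place of 3,5-dichlorophenyl on a carbonyl carbon), so it carries the same aryl group as compound 1 but keeps the amide linkage of compound 2. Within the data shown here, the step bearing on this is the single one from compound 1 to compound 2, which was within the scatter, and it does not isolate the aryl group from the linker. Compound 3 is therefore expected to show no step beyond the scatter, a 1.1-fold higher number from compound 2 to compound 3 (0.04 log units; within the scatter), with an estimate of 1300 nM and a range from 650 nM to 2600 nM in this assay.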

Compound 3, half-maximal inhibitory concentration: 360 nM
The estimate for compound 3 lay 3.6-fold (0.56 log units) above the measured number; measured number below the stated range.
By their numbers in this assay, from the lowest: compound 3; then compounds 2 and 1 (each within the scatter of the next).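

In this assay, the aryl group on the carbonyl carbon matters when the amide-type nitrogen is held fixed: a 3.3-fold lower number from compound 2 to compound 3 (0.52 log units; beyond the scatter), with 4-chloro-3-(trifluoromethyl)phenyl replacing 3,5-dichlorophenyl. The linkage matters too: with the same aryl group on both sides, a 4.0-fold lower number from compound 1 to compound 3 (0.60 log units; beyond the scatter), so the earlier step within the scatter combined two changes, and each of the two new steps lies beyond the scatter. Nothing available explains either step.

Still open, as far as these compounds go, is whether the trifluoromethyl group, the chlorine or their arrangement on the ring accounts for the lower number, which a 4-chlorophenyl or a 3-(trifluoromethyl)phenyl group on the same carbonyl carbon would address. From the compounds shown here alone, it is also open whether the amide linkage keeps its advantage with other aryl groups, such as (3,5-dichlorophenyl)amino set against 3,5-dichlorophenyl.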